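One Ester Changed: Methyl to tert-Butyl

The source may hold more compounds than are shown below. What is called first, only, known or untested is meant among the compounds shown, and "the series" means these compounds.

Of the compounds shown here, two have so far been measured in an assay on isolated protein for inhibition of Voltage-dependent L-type calcium channel subunit alpha-1C (Cavia porcellus); on this read-out higher numbers stand for weaker inhibition and lower numbers for stronger inhibition. Compound 1 `COC(=O)C1=C(C)NC(C)=C(C(=O)OC)C1c1[nH]cnc1Cl` gives 1200 nM, the highest of the two numbers. Compound 2 `CC1=C(C(=O)OC2CCCCC2)C(c2[nH]cnc2Cl)C(C(=O)OC2CCCCC2)=C(C)N1`, which carries cyclohexyl esters instead of the two methyl esters, gives 955 nM; these two values lie within the scatter of each other, so nothing separates them.

Compound 3 `COC(=O)C1=C(C)NC(C)=C(C(=O)OC(C)(C)C)C1c1[nH]cnc1Cl` differs from compound 1 in one place: tert-butyl in place of methyl on an oxygen next to a carbonyl group. Going by the values given here, no measured pair shows exactly this change. Among the compounds with values here, the only guide is that compound 2, with its two much larger ester groups, sits within the scatter of compound 1, which suggests that the size of the ester group matters little here. Compound 3 is therefore expected to give 900 nM, with a range from 300 nM to 2700 nM. The step is estimated as a 1.3-fold lower number from compound 1 to compound 3 (0.12 log units; within the scatter), a small move toward a lower number that stays within the scatter.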

Compound 3, half-maximal inhibitory concentration: 1860 nM
Compound 3: middle estimate off by 2.1-fold (0.32 log units), on the low side; low and high end bracket the measured number.
By their numbers in this assay, from the lowest: compounds 2, 1 and 3 (each within the scatter of the next).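

In this assay, putting tert-butyl in place of methyl on an oxygen next to a carbonyl group gives a 1.6-fold higher number from compound 1 to compound 3 (0.19 log units; within the scatter). Going by these compounds alone, this is the first pair that differs in a single ester, and it shows that four carbons can replace one carbon at this position without a change that stands clear of the usual scatter. No other measurement is available that bears on this result.

The compounds shown leave open whether a group of a different kind on this oxygen, such as a longer chain ending in an amine or a carboxylic acid, would move the number beyond the scatter. As far as these compounds go, it is also open how a compound carrying tert-butyl on both esters would read.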